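The source may report more compounds than this note shows. Statements on the series, on what has been measured and on what is new or still open speak of the compounds shown alone.

Compound 1 `N#CCC(=O)N/N=C1\C(=O)Nc2ccc(S(=O)(=O)N3CCOCC3)cc21` gives 302000 nM
Compound 2 `N=c1oc2ccccc2cc1C(=O)N/N=C1\C(=O)Nc2ccc(S(=O)(=O)N3CCOCC3)cc21` gives 132000 nM

Compound 2 gives 132000 nM in an ADME assay on WI-38 cells (Homo sapiens) for cytotoxicity, read by sulforhodamine B assay, with a stated time of 24 h (on this read-out lower numbers stand for stronger inhibition and higher numbers for weaker inhibition), and holds the lower of the two numbers. The whole change from compound 2 to compound 3 `O=C1Nc2ccc(S(=O)(=O)N3CCOCC3)cc2/C1=N/NC(=O)c1ccccc1` is a group of 6 heavy atoms (6 carbon; one six-membered aromatic ring of carbon only) in place of a group of 11 heavy atoms (9 carbon, 1 nitrogen, 1 oxygen; one six-membered aromatic ring of carbon only, one six-membered aromatic ring with 1 hetero atom), on a carbonyl carbon on the same carbonyl carbon. Within the data shown here, only one measured step bears on it: a 2.3-fold lower number from compound 1 to compound 2 (0.36 log units; beyond the scatter) and that step is modest. On this single step, a small move toward a higher number is expected in this assay and it may well stay within the scatter. The expected change is a 1.4-fold higher number from compound 2 to compound 3 (0.13 log units; within the scatter) and no more than that. Compound 3 is expected at 180000 nM with an estimated range of 70000 nM to 400000 nM around it.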

Compound 3, half-maximal inhibitory concentration: 295000 nM
For compound 3 the middle estimate is 1.6-fold (0.21 log units) below the measured one, within the range that was stated.
By their numbers in this assay, from the lowest: compound 2; then compounds 3 and 1 (each within the scatter of the next).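

In this assay, putting phenyl on the carbonyl carbon undoes the earlier gain, with a 2.2-fold higher number from compound 2 to compound 3 (0.35 log units; beyond the scatter). Phenyl and cyanomethyl at this place cannot be told apart, with a 1.0-fold lower number from compound 1 to compound 3 (0.01 log units; within the scatter), and among these three compounds only the larger group of compound 2 stands apart. No evidence is available that would explain either step.

Going by these compounds, it remains open whether an amine, a carboxylic acid or a longer chain on this carbonyl carbon would move the number beyond the scatter, and in which direction.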